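The compounds below may be only part of what the source reports. "The series", "measured", "known", "first", "only" and "open" are said of these compounds alone.

Series notes. In an ADME assay on NIH3T3 cells (Mus musculus) for cytotoxicity, read by MTT assay, with a stated time of 24 h (on this read-out higher numbers stand for weaker inhibition and lower numbers for stronger inhibition), compound 3 `Cn1nnnc1SCC(=O)N/N=c1/scc(-c2ccc(F)cc2)n1-c1ccccc1` gives 113 ug/mL, the lowest of the three measured numbers; compound 2 `Cc1nnc(SCC(=O)N/N=c2/scc(-c3ccc(F)cc3)n2-c2ccccc2)s1` gives 383 ug/mL and compound 1 `O=C(CSc1nnnn1-c1ccccc1)N/N=c1/scc(-c2ccc(Br)cc2)n1-c1ccccc1` gives 433 ug/mL. Among the measured compounds shown here, the only single-point step measured, a 3.4-fold lower number from compound 2 to compound 3 (0.53 log units; beyond the scatter), concerns the group on the sulfur, not the halogen. Compound 4 `Cn1nnnc1SCC(=O)N/N=c1/scc(-c2ccc(Br)cc2)n1-c1ccccc1` differs from compound 3 by bromo in place of fluoro on an aromatic carbon. For the measured compounds named here, no measured step bears on this change directly; compound 1 and compound 2 differ in the halogen but also in the group on the sulfur, and their two values differ little. Compound 4 is thus expected to show only a 1.2-fold higher number from compound 3 to compound 4 (0.06 log units; within the scatter), nothing beyond the scatter. Compound 4 is estimated at 130 ug/mL, range 55 ug/mL to 320 ug/mL.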

Compound 4, half-maximal inhibitory concentration: 19.3 ug/mL
Beside the measured number, compound 4's estimate is 6.7-fold (0.83 log units) above it; measured number outside the range, below it.
By their numbers in this assay, from the lowest: compound 4; then compound 3; then compounds 2 and 1 (each within the scatter of the next).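

In this assay, the halogen matters when the 1-methyl-1H-tetrazol-5-yl group is on the sulfur: 4-fluorophenyl to 4-bromophenyl gives a 5.9-fold lower number from compound 3 to compound 4 (0.77 log units; beyond the scatter). With bromo held constant, methyl in place of phenyl on an aromatic nitrogen gives a 22-fold lower number from compound 1 to compound 4 (1.35 log units; beyond the scatter), the largest single step seen in this series. No supporting measurement is available to explain either step. On these data alone, it remains open whether bromo lowers the number similarly with 5-methyl-1,3,4-thiadiazol-2-yl on the sulfur. Where chloro or methoxy in the halogen's place would fall is also unknown.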